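Chloro on the phenoxy ring of compound 1

This account rests on a few compounds, and the source may have more. Where it says the series, first, only, none or still open, it means among the compounds named here.

Measured compounds in a functional assay on MIA PaCa-2 cells (Homo sapiens) for antiproliferative activity, read by MTT assay, with a stated time of 72 h; a higher number here means that more compound is needed for the effect, a lower number that less compound is needed:
Compound 1, `CNC(=O)c1cccc(Cn2nc(C)c(NC(=O)c3ccc(COc4ccccc4)cc3)c2C)c1`, gives 6200 nM.
Compound 2, `Cc1nn(Cc2cccc(C(=O)Nc3ccccc3)c2)c(C)c1NC(=O)c1ccc(COc2ccccc2)cc1`, gives 6400 nM.
Compound 3, `CNC(=O)c1cccc(Cn2nc(C)c(NC(=O)c3ccc(COc4cccc(OC)c4)cc3)c2C)c1`, gives 6200 nM.

Compound 1 stands level with compound 3 at the digits given, and the two share the lowest number of the three; its furthest neighbour is compound 2, a 1.0-fold higher number from compound 1 to compound 2 (0.01 log units; within the scatter), which still lies within the scatter. Among the compounds with values here, no compound here is separated from another by more than the scatter.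

Compound 4, `CNC(=O)c1cccc(Cn2nc(C)c(NC(=O)c3ccc(COc4ccc(Cl)cc4)cc3)c2C)c1`, has not yet been measured in this assay. It differs from compound 1 by chloro in place of hydrogen on an aromatic carbon.

Within the data shown here, of the measured steps, the one from compound 1 to compound 3 is the closest relative: a methoxy in place of hydrogen on an aromatic carbon of the same phenoxy ring, no change at the digits printed from compound 1 to compound 3 (within the scatter). The other step, a 1.0-fold higher number from compound 1 to compound 2 (0.01 log units; within the scatter), alters a distant part of the molecule and also stays within the scatter. Neither step gives a reason to expect that a chloro at this position moves the number.

The number for compound 4 in this assay is therefore expected to stay close to that of compound 1, a 1.0-fold lower number from compound 1 to compound 4 (0.01 log units; within the scatter). The estimate for compound 4 is 6000 nM, with a range from 3000 nM to 12000 nM.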

Compound 4, half-maximal effective concentration: 4200 nM
Compound 4: middle estimate off by 1.4-fold (0.15 log units), on the high side; the measured number falls inside the stated range.
By their numbers in this assay, from the lowest: compounds 4, 1, 3 and 2 (each within the scatter of the next).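

In this assay the change from phenyl to 4-chlorophenyl gives a 1.5-fold lower number from compound 1 to compound 4 (0.17 log units; within the scatter) and so shows that this ring carbon, para to a large group, takes a chlorine atom with no step beyond the scatter. The comparison with the 3-methoxyphenyl group gives a 1.5-fold lower number from compound 3 to compound 4 (0.17 log units; within the scatter) and adds that these two differently substituted rings also remain within the scatter of each other. No measurement here bears on why chloro gives this result.

The compounds shown leave open whether any group on this ring can move the number beyond the scatter, for instance an amine or a carboxylic acid on the same carbon. They also leave open how a longer chain in place of the phenoxymethyl group would read in this assay and whether chloro on another ring carbon would match this result.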